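This account rests on a few compounds, and the source may have more. Where it says the series, first, only, none or still open, it means among the compounds named here.

Compound 2 `COC(=O)Cn1c2ccc([N+](=O)[O-])cc2c(=O)n1Cc1ccccc1` gives 129000 nM in an ADME assay on L929 cells (Mus musculus) for cytotoxicity, read by resazurin assay, with a stated time of 48 h (on this read-out higher numbers stand for lower toxicity in this test and lower numbers for higher toxicity in this test), and stands lowest of the two plain numbers, with compound 1 `C=CCn1c2ccc([N+](=O)[O-])cc2c(=O)n1Cc1ccccc1` nearest at 192000 nM. Compound 3 `O=C(O)CCCn1c2ccc([N+](=O)[O-])cc2c(=O)n1Cc1ccccc1` returns only a limit of the assay, > 256000 nM. Of the three values, one sits at the limit of > 256000 nM in this assay, at which 1 of the 3 values shown sits.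

Compound 4 `CN(C)C(=O)CCCn1c2ccc([N+](=O)[O-])cc2c(=O)n1Cc1ccccc1` differs from compound 2 by 2-(dimethylcarbamoyl)ethyl in place of methoxycarbonyl on a saturated chain carbon bound to an aromatic nitrogen. Among the measured compounds shown here, the steps that bear on it are small: an at least 1.9-fold higher number from compound 2 to compound 3 (0.29 log units; that floor lies within the scatter) and a 1.5-fold lower number from compound 1 to compound 2 (0.17 log units; within the scatter). Both chain changes at this position leave the read-out within the scatter, so for compound 4 no step beyond the scatter is expected in this assay, at most a slight drift upward, and the step from compound 2 is estimated as a 1.4-fold higher number from compound 2 to compound 4 (0.14 log units; within the scatter). Compound 4 is expected to give 180000 nM, within 90000 nM to 300000 nM.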

Compound 4, concentration lethal to 50% of the cells: > 256000 nM
Compound 4: a limit, no number; the forecaster's own chance of this, stated with the estimate: 30%; at least 1.4-fold (0.15 log units) between middle value and limit.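

At this position, the 3-(dimethylcarbamoyl)propyl chain of compound 4 gives a limit rather than a number, as the carboxylic acid chain of compound 3 does, so an amide end also reaches the limit in this assay: the limit of > 256000 nM in this assay, at which 2 of the 4 values shown sit.

The readable steps, an at least 1.9-fold higher number from compound 2 to compound 4 (0.29 log units; that floor lies within the scatter) and an at least 1.3-fold higher number from compound 1 to compound 4 (0.12 log units; that floor lies within the scatter), both have floors within the scatter, so no separation from compound 1 or compound 2 is established. The step between compound 3 and compound 4 cannot be read.

Open, going by these compounds, is whether a chain ending in an amine, or a longer chain, would give a plain number in this assay.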